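Methoxymethoxy in place of butoxy: what to expect

The source may hold more compounds than are shown below. What is called first, only, known or untested is meant among the compounds shown, and "the series" means these compounds.

Compound 1 `COc1ccc(/C=N/NC(N)=S)c2ccccc12` and compound 2 `CCCCOc1ccc(/C=N/NC(N)=S)c2ccccc12` differ only in the chain on the aromatic ether oxygen. In a toxicity assay on THP-1 cells (Homo sapiens) for cytotoxicity, read by MTT assay, with a stated time of 72 h (a higher number here means that more compound is needed for the effect, a lower number that less compound is needed), compound 1 gives 47000 nM. For compound 2 the result in this assay is only a limit, > 200000 nM, so the limit of > 200000 nM in this assay, at which 1 of the 2 values shown sits, marks where compound 2 stands. The step of an at least 4.2-fold higher number from compound 1 to compound 2 (0.62 log units; beyond the scatter) thus has a known floor but no known ceiling. Compound 3 `COCOc1ccc(/C=N/NC(N)=S)c2ccccc12` is not yet measured; it differs from compound 2 by methoxy in place of propyl on a saturated chain carbon bound to an oxygen on an aromatic ring. For the measured compounds named here, the one measured step bearing on it is an at least 4.2-fold higher number from compound 1 to compound 2 (0.62 log units; beyond the scatter), where going from methoxy to butoxy raised the number, and methoxymethoxy sits between those two in chain length. The step from compound 2 to compound 3 is therefore expected to move downward toward compound 1, its size uncertain because compound 2 is known only as a limit (the limit of > 200000 nM in this assay, at which 1 of the 2 values shown sits). The estimate for compound 3 in this assay is 110000 nM, ranging from 45000 nM to 250000 nM, an expected step of an at least 1.8-fold lower number from compound 2 to compound 3 (0.25 log units; that floor lies within the scatter).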

Compound 3, half-maximal effective concentration: > 200000 nM
Compound 3 was reported as a limit (the forecaster's own chance of this, stated with the estimate: 40%); middle value at least 1.8-fold (0.25 log units) away from the limit.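

Replacing methoxy with methoxymethoxy on the shared core is enough to raise the number in this assay: an at least 4.2-fold higher number from compound 1 to compound 3 (0.62 log units; beyond the scatter). The rise therefore does not require the all-carbon butoxy chain, since a chain with an oxygen in it also produces a step of this kind. Compound 2 and compound 3 both stand only as limits, so the step between them cannot be read and neither can be placed ahead of the other: the limit of > 200000 nM in this assay, at which 2 of the 3 values shown sit.

Going by these compounds, how far past this limit either compound lies remains open, as does whether swapping butyl for methoxymethyl makes any difference at all. Also open, on these data alone, is whether an ethoxy group, a longer chain, or a chain ending in an amine or a carboxylic acid would stay at this limit or fall back toward compound 1.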